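A few compounds are considered here, and "the series" means these few. Any claim that something is new, unique, unknown or untested is made for them only; others in the source may bear on it.

Measured so far in a functional assay on UACC-62 cells (Homo sapiens) for inhibition, read by sulforhodamine B assay, with a stated time of 48 h; a higher number here means a weaker inhibitor of growth, a lower number a stronger inhibitor of growth:
Compound 1 `Cc1ccc(NC(=O)/C=C/c2ccccc2)c(C(N)=O)c1`: 3770 nM
Compound 2 `NC(=O)c1cc(I)ccc1NC(=O)/C=C/c1ccccc1`: 632 nM

Compound 2 holds the lower of these two numbers, so it is the stronger inhibitor of growth. Compound 3 `NC(=O)c1cc(I)ccc1NC(=O)/C=C/c1ccccc1Cl` makes one change to it: chloro in place of hydrogen on an aromatic carbon. This puts chloro in place of hydrogen on an aromatic carbon, ortho to a large group, turning phenyl into 2-chlorophenyl.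

Among the measured compounds shown here, only one measured step is available as a guide. Iodo in place of methyl on an aromatic carbon gave a 6.0-fold lower number from compound 1 to compound 2 (0.78 log units; beyond the scatter). That modest step involved a different swap on a different aromatic carbon, so it bears only weakly on this change. For the measured compounds named here, no measured compound carries a chloro, so no step beyond the scatter is expected in this assay. The expected step is a 1.4-fold lower number from compound 2 to compound 3 (0.15 log units; within the scatter). The estimate for compound 3 is 450 nM, with an expected range of 160 nM to 1300 nM.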

Compound 3, concentration for 50% growth inhibition: 388 nM
Beside the measured number, compound 3's estimate is 1.2-fold (0.06 log units) above it, within the range that was stated.
By their numbers in this assay, from the lowest: compounds 3 and 2 (each within the scatter of the next); then compound 1.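

In this assay the swap of phenyl for 2-chlorophenyl gives a 1.6-fold lower number from compound 2 to compound 3 (0.21 log units; within the scatter) and so cannot be told apart from repeat-measurement noise. Among the compounds shown here, this is the first look at the phenyl end of the series, since the earlier step changed a different aromatic carbon, and it shows that a chloro on this carbon, ortho to a large group, leaves the growth-inhibition reading essentially where it was. Nothing measured here gives a reason for this outcome. On these data alone, whether a methoxy, an amine or a carboxylic acid on the same carbon would also leave the number in place remains open. So does whether a chloro on another carbon of the phenyl, or the same chloro paired with the methyl of compound 1, would behave alike.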